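Imidazoline Ethers at the Alpha-1B Receptor: Toward Compound 4

The source may report more compounds than this note shows. Statements on the series, on what has been measured and on what is new or still open speak of the compounds shown alone.

Measured so far, in a functional assay for activation of Alpha-1B adrenergic receptor (Homo sapiens), read by calcium flux; a higher number here means that more compound is needed for the effect, a lower number that less compound is needed:
- compound 1, `CCN(CC)C(=O)c1ccccc1OCC1=NCCN1`: compound 1 gives < 5020 nM
- compound 2, `Cc1cccnc1-c1ccccc1OCC1=NCCN1`: compound 2 gives < 100000 nM
- compound 3, `c1ccc(-c2ccncn2)c(OCC2=NCCN2)c1`: compound 3 gives < 100000 nM

Every one of these three results is a limit of this assay rather than a measured number. For compound 3 the value is a limit, and it sits at the limit of < 100000 nM in this assay, at which 2 of the 3 values shown sit. Compound 2 sits at that same limit. Compound 1 sits at a different one, (the limit of < 5020 nM in this assay, at which 1 of the 3 values shown sits). No pair of these compounds differs in just one place, so no measured step exists, and the three results cannot be ranked against each other.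

The next compound, compound 4, `c1ccc(-c2ncc[nH]2)c(OCC2=NCCN2)c1`, changes compound 3 in one place: 1H-imidazol-2-yl in place of pyrimidin-4-yl on an aromatic carbon. Among the compounds with values here, since no step between measured compounds is known here, there is nothing to say in which direction this change should move the result in this assay, or whether it moves it beyond the usual scatter at all. The expectation therefore stays close to the range that compound 3 occupies. For compound 4 the estimate in this assay is 5000 nM, with a range from 300 nM to 50000 nM. The step that this estimate implies is expected to be a step that the limit leaves unreadable from compound 3 to compound 4.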

Compound 4, half-maximal effective concentration: < 100000 nM
Compound 4: a limit, no number (the forecaster's own chance of this, stated with the estimate: 45%); the middle value lies beyond the limit too.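

In this assay compound 4 gives < 100000 nM, which is a limit and not a number. Within the data shown here, compound 3 also stands at a limit, and no step between compound 3 and compound 4 can be read. The compounds shown leave open whether 1H-imidazol-2-yl in place of pyrimidin-4-yl on an aromatic carbon changes the result at all, and in which direction.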